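Fluoro to Chloro on the Aromatic Ring of Compound 2

The compounds below may be only part of what the source reports. "The series", "measured", "known", "first", "only" and "open" are said of these compounds alone.

Compound 2 `CSc1ccc(F)cc1NCC1=NCCN1` gives 2.29 nM in a functional assay for agonist activity at Alpha-1A adrenergic receptor (Homo sapiens) (a higher number here means that more compound is needed for the effect, a lower number that less compound is needed), the lowest of the three numbers recorded. Compound 3 `CSc1cc(F)ccc1NCC1=NCCN1` gives 7.76 nM, and compound 1 `CS(=O)(=O)c1ccc(F)cc1NCC1=NCCN1` gives 16.6 nM; the step of a 7.2-fold lower number from compound 1 to compound 2 (0.86 log units; beyond the scatter) arises from methylsulfanyl in place of methylsulfonyl on an aromatic carbon. Compound 4 `CSc1ccc(Cl)cc1NCC1=NCCN1` differs from compound 2 by chloro in place of fluoro on an aromatic carbon. Going by the values given here, no measured step exchanges these two halogens, and the single measured step concerns a different group, so it offers only a weak guide here. The writer therefore expects a step of a 1.1-fold higher number from compound 2 to compound 4 (0.04 log units; within the scatter), within the scatter. The estimate for compound 4 in this assay is 2.5 nM, with a range from 0.9 nM to 7 nM.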

Compound 4, half-maximal effective concentration: 0.437 nM
Compound 4: middle estimate off by 5.7-fold (0.76 log units), on the high side, outside the stated range (below it).
By their numbers in this assay, from the lowest: compound 4; then compound 2; then compound 3; then compound 1.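

Going by these compounds alone, this is the first measured change at this place, on an aromatic carbon para to a methylsulfanyl group, and it shows that the halogen there matters in this assay: chloro in place of fluoro gives a 5.2-fold lower number from compound 2 to compound 4 (0.72 log units; beyond the scatter), a step as clear as the earlier one at the sulfur group. Nothing shown gives a reason for this step.

The compounds shown leave open whether bromo or methyl at this place would lower the number further. They also leave open whether chloro in place of fluoro would give a similar step with methylsulfonyl in place of methylsulfanyl.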